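A few compounds are considered here, and "the series" means these few. Any claim that something is new, unique, unknown or untested is made for them only; others in the source may bear on it.

Compound 1 `CCN(Cc1cccs1)C(=O)COc1ccc(F)cc1` sets the reference point for this small set: in an assay on HEK293 cells for agonist activity at transient receptor potential cation channel subfamily M member 8 (Homo sapiens), read by fluorescence and calcium flux, with a stated time of 15 min (on this read-out higher numbers stand for an effect only at larger amounts of compound and lower numbers for an effect already at smaller amounts), compound 1 gives 422 nM. Compound 2 `CCN(C(=O)COc1ccc(C)cc1)C(C)c1cccs1` is a different case, since in this assay compound 2 is reported as "not active" (no number reported), with no number attached to it. Compound 3 `Cc1ccc(OCC(=O)N(Cc2cccs2)c2ccnn2C)cc1` in this assay gives 422 nM, which stands level with compound 1 within the scatter, and compound 2 offers no number for comparison. The move from compound 3 to compound 4 `Cc1ccc(OCC(=O)N(Cc2cccs2)c2cnccn2)cc1` is pyrazin-2-yl in place of 1-methyl-1H-pyrazol-5-yl on an amide-type nitrogen. Among the compounds with values here, no measured pair in the set isolates a change of this kind, so its direction rests on judgement alone; the leaving and entering groups match in what is counted, which argues for a modest step rather than a large one. In this assay compound 4 is expected to give about 650 nM, within a range of 200 nM to 2500 nM. The expected step of a 1.5-fold higher number from compound 3 to compound 4 (0.19 log units; within the scatter) is a slight drift toward larger amounts, not clearly beyond the scatter, and the outcome seen with compound 2 leaves a real chance that no number is returned.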

Compound 4, half-maximal effective concentration: 1240 nM
Compound 4: the middle estimate sits 1.9-fold (0.28 log units) below what was measured, within the range that was stated.
By their numbers in this assay, from the lowest: compounds 1 and 3 (each within the scatter of the next); then compound 4.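

In this assay the exchange of 1-methyl-1H-pyrazol-5-yl for pyrazin-2-yl on the amide-type nitrogen brings a 2.9-fold higher number from compound 3 to compound 4 (0.47 log units; beyond the scatter) and gives the first sign that the number responds to which aromatic ring sits at this place. The two groups match in heavy atoms, carbon, nitrogen, donors and acceptors and differ in ring size, five-membered against six-membered, so these matching counts alone do not fix the number here. Nothing at hand accounts for the step.

Going by these compounds, whether a phenyl or a pyridin-2-yl group on the same nitrogen would stand with compound 3 or with compound 4 remains open. Compound 1 and compound 2 each differ from compound 3 in more than one place, so what a simple chain on this nitrogen does also stays unresolved.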